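Replacing the ethoxyphenyl arm of compound 1 with a thiophene

The compounds below may be only part of what the source reports. "The series", "measured", "known", "first", "only" and "open" are said of these compounds alone.

Compound 1 `CCOc1cccc(-c2ccc([C@H]3S[C@@H](C)C(=O)Nc4c3c(C)nn4-c3ccccc3C)cc2)c1` is the weakest of the three measured compounds in an assay on isolated protein for agonist activity at Bile acid receptor (Homo sapiens), read by AlphaScreen, with a stated time of 30 min (on this read-out higher numbers stand for larger maximal responses and lower numbers for smaller maximal responses), where compound 1 gives 13%. Compound 3 `Cc1nn(-c2ccccc2Cl)c2c1C(c1ccc(Oc3ccccc3)cc1)SC(C)C(=O)N2` gives 57%, and compound 2 `Cc1nn(-c2ccccc2I)c2c1C(c1ccc(Oc3ccccc3)cc1)SC(C)C(=O)N2` gives 130%. For the measured compounds named here, the only single-point step measured so far is a number 73 percentage points lower from compound 2 to compound 3 (beyond the scatter), a change at the group on the pyrazole nitrogen, not at the arm varied here. Compound 4 `Cc1ccccc1-n1nc(C)c2c1NC(=O)[C@H](C)S[C@@H]2c1ccc(-c2ccsc2)cc1` differs from compound 1 by thiophen-3-yl in place of 3-ethoxyphenyl on an aromatic carbon. Going by the values given here, no measured step touches this arm, so the direction of the change is not supported by data; the large swing seen in a number 73 percentage points lower from compound 2 to compound 3 (beyond the scatter) only shows the series can move widely. The expected step is a number 22 percentage points higher from compound 1 to compound 4 (beyond the scatter), with an estimate for compound 4 of 35% (range 8% to 90%).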

Compound 4, largest response reached (reported as efficacy), in percent of the reference or control that the assay uses: 68%
For compound 4 the middle estimate is 33 percentage points below the measured one; measured number inside the range.
By their numbers in this assay, from the lowest: compound 1; then compound 3; then compound 4; then compound 2.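

The aromatic arm para to a large group is a sensitive position in its own right: thiophen-3-yl in place of 3-ethoxyphenyl gives a number 55 percentage points higher from compound 1 to compound 4 (beyond the scatter). The maximal response therefore depends on this arm, not only on the halogen changed in the earlier step. No measured data explain the rise at this position.

Open, as far as these compounds go, is whether the gain follows from the thiophene ring or from the loss of the ethoxy group. A plain phenyl or a 3-aminophenyl arm on the same core would help to separate the two.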